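The source may hold more compounds than are shown below. What is called first, only, known or untested is meant among the compounds shown, and "the series" means these compounds.

Working notes on the series. Compound 1 `O=C1OC[C@H](Cc2ccccc2)[C@H]1Cc1ccccc1OC(F)(F)F` gives 39000 nM in a functional assay on HL-60 cells (Homo sapiens) for cytotoxicity, read by WST assay, with a stated time of 48 h; a lower number here means that less compound is needed, a higher number that more compound is needed for the effect. Compound 2 `CCCCCCCOc1ccccc1C[C@H]1C(=O)OC[C@@H]1Cc1ccccc1` gives 75000 nM in this assay, and compound 3 `O=C1OC[C@H](Cc2ccccc2)[C@H]1Cc1ccccc1F` gives 72000 nM in this assay. Among the measured compounds shown here, the steps so far, a 1.9-fold higher number from compound 1 to compound 2 (0.28 log units; within the scatter), a 1.8-fold higher number from compound 1 to compound 3 (0.27 log units; within the scatter) and a 1.0-fold lower number from compound 2 to compound 3 (0.02 log units; within the scatter), all stay within the scatter. Compound 3 stands second highest of the three numbers in this assay, with compound 2 nearest and compound 1 furthest, both within the scatter. Compound 4 `O=C1OC[C@H](Cc2ccccc2)[C@H]1Cc1ccc(Cl)cc1` differs from compound 3 as follows: 4-chlorophenyl in place of 2-fluorophenyl on a saturated chain carbon bound to a saturated ring carbon. For the measured compounds named here, no measured step alters this aryl group itself; every step seen was within the scatter. A step of a 1.2-fold lower number from compound 3 to compound 4 (0.08 log units; within the scatter) is expected, also within the scatter. Compound 4 is estimated at 60000 nM in this assay, with a range of 25000 nM to 150000 nM.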

Compound 4, half-maximal effective concentration: 36000 nM
Compound 4: middle estimate off by 1.7-fold (0.22 log units), on the high side, within the range that was stated.
By their numbers in this assay, from the lowest: compounds 4, 1, 3 and 2 (each within the scatter of the next, the first and the last beyond it).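

Swapping 2-fluorophenyl for 4-chlorophenyl gives a 2.0-fold lower number from compound 3 to compound 4 (0.30 log units; within the scatter) in this assay, so at this place a change of both the halogen and its location on the aryl group still stays within the scatter. The earlier steps shown here exchanged only the substituent at one location on this aryl group, and this single step cannot separate the halogen from its location. No evidence bears on the origin of this step.

2-Chlorophenyl and 4-fluorophenyl would separate the two changes. As far as these compounds go, whether an amine or a carboxylic acid on this aryl group would move the number beyond the scatter remains open.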